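A Sulfonyl Phenyl Amide Judged Against Two Weak Neighbours

This account rests on a few compounds, and the source may have more. Where it says the series, first, only, none or still open, it means among the compounds named here.

Among the measured compounds shown here, compound 1 `O=C(Nc1ccc(Cl)c(-c2nnc3c(Cl)cccn23)c1)c1ccccn1` is the only compound here with a numerical result: in a functional assay on U-251 cells (Homo sapiens) for antiproliferative activity, read by MTT assay, with a stated time of 72 h (a lower number here means a stronger inhibitor, a higher number a weaker inhibitor), compound 1 gives 79000 nM. Compound 2 `O=C(Nc1ccc(Cl)c(-c2nnc3c(Cl)cccn23)c1)c1ccc(Cl)cc1Cl` reaches only a limit of this assay, giving > 100000 nM. That single measured step is an at least 1.2-fold higher number from compound 1 to compound 2 (0.10 log units; that floor lies within the scatter). Compound 3 `CS(=O)(=O)c1cccc(C(=O)Nc2ccc(Cl)c(-c3nnc4c(Cl)cccn34)c2)c1` differs from compound 1 in one place: 3-(methylsulfonyl)phenyl in place of pyridin-2-yl on a carbonyl carbon. For the measured compounds named here, the one measured step also exchanged pyridin-2-yl on that carbonyl carbon and ran to the limit of > 100000 nM in this assay, at which 1 of the 2 values shown sits, so the expected step here is estimated as a 1.1-fold higher number from compound 1 to compound 3 (0.06 log units; within the scatter). Compound 3 is therefore expected to give about 90000 nM, between 30000 nM and 300000 nM.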

Compound 3, half-maximal inhibitory concentration: > 100000 nM
Compound 3: no number, only a limit (the forecaster's own chance of this, stated with the estimate: 55%); middle value at least 1.1-fold (0.04 log units) from the limit.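

Placing 3-(methylsulfonyl)phenyl on the carbonyl carbon instead of pyridin-2-yl gives an at least 1.2-fold higher number from compound 1 to compound 3 (0.10 log units; that floor lies within the scatter). The second replacement of pyridin-2-yl shown here therefore also ends at a limit in this assay, and the step from compound 2 to compound 3 cannot be read, as both are limits. Only compound 1 keeps a number at this position: the limit of > 100000 nM in this assay, at which 2 of the 3 values shown sit.

On these data alone, how much weaker compound 2 and compound 3 truly are remains unknown. Also open, as far as these compounds go, is whether an amine or a carboxylic acid on the phenyl ring at this position would give a measurable number.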